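Acetamido to 4-methylpiperidin-1-yl on two related cores

The source may report more compounds than this note shows. Statements on the series, on what has been measured and on what is new or still open speak of the compounds shown alone.

Measured so far in a functional assay for inhibition, with Homo sapiens as the target; a higher number here means a weaker inhibitor, a lower number a stronger inhibitor:
compound 1 `CC(=O)Nc1cccc(Nc2nccc(-c3cccnc3)n2)c1` gives 3600 nM
compound 2 `CC1CCN(c2cccc(Nc3nccc(-c4cccnc4)n3)c2)CC1` gives 1200 nM
compound 3 `CC(=O)Nc1ccc(Nc2nccc(-c3ccncc3)n2)cc1` gives 5300 nM

Compound 1 and compound 2 differ in one place: 4-methylpiperidin-1-yl in place of acetamido on an aromatic carbon. The step that goes with it is a 3.0-fold lower number from compound 1 to compound 2 (0.48 log units; beyond the scatter), a modest gain for the compound carrying the ring.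

Compound 3 is built from the same atoms as compound 1, joined differently; the difference between the two cores is not broken down here. In this assay the values of compound 3 and compound 1 lie within the usual scatter of each other, so nothing is read into their order. The gap between compound 3 and compound 2 is wider and lies beyond the scatter.

Compound 4 `CC1CCN(c2ccc(Nc3nccc(-c4ccncc4)n3)cc2)CC1` has not yet been measured. It stands to compound 3 as compound 2 stands to compound 1: 4-methylpiperidin-1-yl in place of acetamido on an aromatic carbon. This is the same kind of change, not the same change, for the place differs: here the group sits para to a large group, whereas in the pair of compound 1 and compound 2 it sits meta to a large group.

For the measured compounds named here, on that basis the step from compound 3 to compound 4 is expected to be of similar size, a 2.9-fold lower number from compound 3 to compound 4 (0.47 log units; beyond the scatter), because the one measured instance of this change, a 3.0-fold lower number from compound 1 to compound 2 (0.48 log units; beyond the scatter), gave a modest gain. The wider range allows for the different place. Compound 4 is therefore estimated at 1800 nM, with a likely span from 600 nM to 5300 nM.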

Compound 4, half-maximal inhibitory concentration: 600 nM
The estimate for compound 4 lay 3.0-fold (0.48 log units) above the measured number; measured number inside the range.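

In this assay the replacement of acetamido by 4-methylpiperidin-1-yl on the second core gives an 8.8-fold lower number from compound 3 to compound 4 (0.95 log units; beyond the scatter) and so keeps the direction of the earlier step. The direction carries across the two cores, but the size does not carry over unchanged: the same change on two cores in this assay, a 3.0-fold lower number (0.48 log units; beyond the scatter) from compound 1 to compound 2 and an 8.8-fold lower number (0.95 log units; beyond the scatter) from compound 3 to compound 4, 2.9-fold (0.47 log units) apart, beyond the scatter of two such steps. This shows that the gain from the change depends on its setting in this pair of cores, yet two pairs give no general rule, and the cores differ in how the same atoms are joined, so the larger step cannot be assigned to any single feature, including the place of the group, para to a large group in compound 4.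

The compounds shown do not separate the place of the group on the aromatic ring from the other differences between the two cores, so a compound that alters only one of these would be needed to say which of them goes with the larger step. As far as these compounds go, it also remains open whether the step belongs to 4-methylpiperidin-1-yl in particular or extends to related groups such as unsubstituted piperidine, morpholine or piperazine on the same aromatic carbon.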